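The compounds below may be only part of what the source reports. "The series", "measured", "known", "first", "only" and "open" are said of these compounds alone.

In a functional assay on MCF7 cells (Homo sapiens) for antiproliferative activity, read by MTT assay, with a stated time of 48 h (a lower number here means a stronger inhibitor, a higher number a weaker inhibitor), the measured compounds are:

compound 1, `CCn1c(C(=O)NCCN(C)C)ccc1C(CC)(CC)c1ccc(OCCC(O)(CC)CC)c(C)c1`: 430 nM
compound 2, `CCN(CC)CCNC(=O)c1ccc(C(CC)(CC)c2ccc(OCCC(O)(CC)CC)c(C)c2)n1CC`: 550 nM
compound 3, `CCOC(=O)CN(C)C(=O)c1ccc(C(CC)(CC)c2ccc(OCCC(O)(CC)CC)c(C)c2)n1CC`: 3210 nM

Compound 1 has the lowest number of the three; compound 2 sits within the scatter of it a 1.3-fold higher number from compound 1 to compound 2 (0.11 log units; within the scatter), and only compound 3 stands beyond it a 7.5-fold higher number from compound 1 to compound 3 (0.87 log units; beyond the scatter). Compound 4, `CCn1c(C(=O)NC(CC(=O)O)C(=O)OC)ccc1C(CC)(CC)c1ccc(OCCC(O)(CC)CC)c(C)c1`, differs from compound 1 in one place: a group of 9 heavy atoms (5 carbon, 4 oxygen; no ring) in place of a group of 5 heavy atoms (4 carbon, 1 nitrogen; no ring), on an amide-type nitrogen. The step that bears on this is the one in which the amine-bearing chain was replaced by an ester-bearing group, from compound 1 to compound 3 a 7.5-fold higher number from compound 1 to compound 3 (0.87 log units; beyond the scatter), with the parallel step a 5.8-fold higher number from compound 2 to compound 3 (0.77 log units; beyond the scatter). Both point the same way, a modest rise in the number, and a modest rise beyond the scatter is therefore expected for compound 4 in this assay. Compound 4 is estimated at 2500 nM, with a range from 900 nM to 7000 nM, which would mean a step of a 5.8-fold higher number from compound 1 to compound 4 (0.76 log units; beyond the scatter).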

Compound 4, half-maximal inhibitory concentration: 10200 nM
Estimate against measurement, compound 4: 4.1-fold (0.61 log units) below; the measured number lies above the stated range.
By their numbers in this assay, from the lowest: compounds 1 and 2 (each within the scatter of the next); then compound 3; then compound 4.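

Within the data shown here, on the amide-type nitrogen, the step of a 24-fold higher number from compound 1 to compound 4 (1.38 log units; beyond the scatter) in this assay and the step of a 19-fold higher number from compound 2 to compound 4 (1.27 log units; beyond the scatter) are both large, so this replacement of the amine-bearing chain costs more than any change among the earlier compounds. The step of a 3.2-fold higher number from compound 3 to compound 4 (0.50 log units; beyond the scatter) shows that the ester-bearing groups on the carbonyl carbon are not equivalent either. No measurement shown here accounts for these rises. The compounds leave open whether a 3-(dimethylamino)propyl chain on that nitrogen would stay within the scatter of compound 1. They also leave open how a piperidine ring at the chain end would read.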